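Piperidinyl in place of fluoropyridinyl on a shared core

This account rests on a few compounds, and the source may have more. Where it says the series, first, only, none or still open, it means among the compounds named here.

Measured so far in a functional assay on HEK293 cells for agonist activity at Bombesin receptor subtype-3 (Mus musculus), read by luminescence and calcium flux, with a stated time of 10 min; on this read-out higher numbers stand for an effect only at larger amounts of compound and lower numbers for an effect already at smaller amounts:
compound 1 `CCC(C)(C)Cc1c[nH]c(CCc2ccc(-c3cccc(C#N)n3)cc2)n1` gives 115 nM
compound 2 `CCC(C)(C)Cc1c[nH]c(CCc2ccc(-c3ccccc3C(=O)O)cc2)n1` gives 94 nM
compound 3 `CCC(C)(C)Cc1c[nH]c(CCc2ccc(-c3ccc(F)cn3)cc2)n1` gives 105 nM

All three compounds share one core and differ only in the group on the aromatic carbon. Compound 3 sits among three numbers that lie within the scatter of one another: the step of a 1.1-fold lower number from compound 1 to compound 3 (0.04 log units; within the scatter) and the step of a 1.1-fold higher number from compound 2 to compound 3 (0.05 log units; within the scatter) are both small, so compound 3 is neither set apart from compound 1 nor from compound 2 by the data.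

Compound 4 `CCC(C)(C)Cc1c[nH]c(CCc2ccc(N3CCCCC3)cc2)n1` has not yet been measured in this assay. Its change from compound 3 is piperidin-1-yl in place of 5-fluoropyridin-2-yl on an aromatic carbon. For the measured compounds named here, the steps that bear on it are a 1.2-fold lower number from compound 1 to compound 2 (0.09 log units; within the scatter), a 1.1-fold lower number from compound 1 to compound 3 (0.04 log units; within the scatter) and a 1.1-fold higher number from compound 2 to compound 3 (0.05 log units; within the scatter), each within the scatter, which shows that exchanging one aromatic group for another at this carbon left the number unchanged. None of those steps, however, replaces an aromatic ring with a non-aromatic one, so the precedent is only partial.

Compound 4 is therefore expected to give about 200 nM in this assay, within 60 nM to 700 nM. Going by the values given here, the expected step of a 1.9-fold higher number from compound 3 to compound 4 (0.28 log units; within the scatter) is drawn wide, since no measured step covers an aromatic-to-non-aromatic exchange.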

Compound 4, half-maximal effective concentration: 133 nM
The estimate for compound 4 lay 1.5-fold (0.18 log units) above the measured number, and the stated range covers the measured number.
By their numbers in this assay, from the lowest: compounds 2, 3, 1 and 4 (each within the scatter of the next).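

In this assay, the step of a 1.3-fold higher number from compound 3 to compound 4 (0.10 log units; within the scatter) is the first among these compounds to put a non-aromatic ring, piperidin-1-yl, on this aromatic carbon in place of an aromatic one, and the steps of a 1.4-fold higher number from compound 2 to compound 4 (0.15 log units; within the scatter) and a 1.2-fold higher number from compound 1 to compound 4 (0.06 log units; within the scatter) read the same way. At this place, on an aromatic carbon para to a large group, the number therefore does not depend on the entering ring being aromatic: 5-fluoropyridin-2-yl, 2-carboxyphenyl, 6-cyanopyridin-2-yl and piperidin-1-yl all give values within the scatter of one another, and none of the four goes against this. Nothing measured on these compounds speaks to why the number holds across this exchange.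

From the compounds shown here alone, all four groups are six-membered rings, so it remains open whether a five-membered pyrrolidin-1-yl ring, an open chain such as butyl or a simple amine at this carbon would also leave the number in the same range. The compounds also leave open how a morpholin-4-yl or piperazin-1-yl ring would read in this assay.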